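This account rests on a few compounds, and the source may have more. Where it says the series, first, only, none or still open, it means among the compounds named here.

Compound 1 `CC[C@H](C)[C@H](N)CN(C(=O)[C@@H]1C[C@H]1c1cc(F)ccc1F)c1ccc(-c2ccccc2)cc1`: 770 nM
Compound 2 `CC[C@H](C)[C@H](N)CN(C(=O)[C@@H]1C[C@H]1c1ccsc1)c1ccc(-c2ccccc2)cc1`: 450 nM
Compound 3 `CC(C)C[C@H](N)CN(C(=O)[C@@H]1C[C@H]1c1ccccc1)c1ccc(C2=CCCCC2)cc1`: 1200 nM

In a functional assay for agonist activity at G protein-coupled receptor 88 (Homo sapiens), read by HTRF and cAMP accumulation (on this read-out lower numbers stand for an effect already at smaller amounts and higher numbers for an effect only at larger amounts of compound), compound 3 gives the highest of the three numbers. Its gap to compound 1 lies within the scatter, while its gap to compound 2 lies beyond it. Going by the values given here, the one single-point step, a 1.7-fold lower number from compound 1 to compound 2 (0.23 log units; within the scatter), swaps a ring on a saturated ring carbon and lies within the scatter.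

Compound 4 `CC(C)C[C@H](N)CN(C(=O)[C@@H]1C[C@H]1c1ccccc1)c1ccc(-c2ccccc2F)cc1` differs from compound 3 in one place: 2-fluorophenyl in place of cyclohex-1-en-1-yl on an aromatic carbon. Among the compounds with values here, no measured step touches the group on that aromatic carbon, so the change has no precedent here and little shift beyond the scatter is expected, with wide uncertainty. The expected step is a 1.2-fold lower number from compound 3 to compound 4 (0.08 log units; within the scatter). Compound 4 is therefore estimated at 1000 nM, between 400 nM and 2500 nM.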

Compound 4, half-maximal effective concentration: 1600 nM
The estimate for compound 4 lay 1.6-fold (0.20 log units) below the measured number; measured number inside the range.
By their numbers in this assay, from the lowest: compounds 2, 1, 3 and 4 (each within the scatter of the next, the first and the last beyond it).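

In this assay, replacing cyclohex-1-en-1-yl with 2-fluorophenyl gives a 1.3-fold higher number from compound 3 to compound 4 (0.12 log units; within the scatter), so the assay does not separate these two rings at this aromatic carbon. Going by these compounds alone, this is the first step here to touch that position, as the earlier step changed a group on a saturated ring carbon. No supporting evidence bears on this result. Still open, going by these compounds, is whether an amine or a carboxylic acid at this position would move the number beyond the scatter. Also open, on these data alone, is whether a phenyl ring without fluorine would behave like 2-fluorophenyl on the core of compound 4.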